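This account rests on a few compounds, and the source may have more. Where it says the series, first, only, none or still open, it means among the compounds named here.

In a functional assay on HEK293 cells for agonist activity at metabotropic glutamate receptor 6 (Homo sapiens), read by a luciferase reporter and cAMP accumulation (on this read-out lower numbers stand for an effect already at smaller amounts and higher numbers for an effect only at larger amounts of compound), compound 2 `Fc1ccccc1N1CCN(Cc2ccn3c(CC4CC4)nnc3c2C(F)(F)F)CC1` gives only a limit of the assay, > 10000 nM. Compound 1 `Fc1ccc(N2CCN(Cc3ccn4c(CC5CC5)nnc4c3C(F)(F)F)CC2)c(Cl)c1` likewise reaches only a limit in this assay, > 10000 nM. For the measured compounds named here, the single measured step, a step that the two limits leave unreadable from compound 1 to compound 2, therefore has no readable size, since (the limit of > 10000 nM in this assay, at which 2 of the 2 values shown sit). Compound 3 `Fc1ccc(N2CCN(Cc3ccn4c(CC5CC5)nnc4c3C(F)(F)F)CC2)c(F)c1` differs from compound 2 by fluoro in place of hydrogen on an aromatic carbon. Going by the values given here, no measured step bears on this change, so nothing beyond the scatter is expected in this assay, and compound 3 is expected to remain at the limit as well. The expected change is a step that the limit leaves unreadable from compound 2 to compound 3. Compound 3 is estimated at 20000 nM, between 5000 nM and 60000 nM.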

Compound 3, half-maximal effective concentration: > 8000 nM
Compound 3: no number, only a limit (the forecaster's own chance of this, stated with the estimate: 80%); the middle value lies beyond the limit too.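

For the compounds shown here, compound 1, compound 2 and compound 3 all give only limits, not numbers, so no step between them can be read. The compounds shown leave open whether changing the groups on this aromatic ring alters activity at all.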